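Hydrogen for Chloro on the Benzyl Ring: Expected Weaker Cytotoxicity

The compounds below may be only part of what the source reports. "The series", "measured", "known", "first", "only" and "open" are said of these compounds alone.

Compound 1 `Nc1cccc(/C=C2\SC(=O)N(Cc3ccccc3)C2=O)c1`: in a functional assay on CCRF-CEM cells (Homo sapiens) for cytotoxicity, read by cell counting, with a stated time of 3 days (on this read-out higher numbers stand for weaker inhibition and lower numbers for stronger inhibition), compound 1 gives > 250000 nM, which is a limit of the assay and not a number.
Compound 2 `Nc1ccc(/C=C2\SC(=O)N(Cc3ccc(Cl)cc3)C2=O)cc1`: in this assay compound 2 gives 87000 nM.

Within the data shown here, compound 2 therefore stands as the only compound with a number in this assay; the one other value is a limit.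

Compound 3 `Nc1ccc(/C=C2\SC(=O)N(Cc3ccccc3)C2=O)cc1` arises from compound 2 by hydrogen in place of chloro on an aromatic carbon. Among the measured compounds shown here, no step between two measured compounds is available to size this change, so its effect can only be guessed. The expectation is a step in this assay of a 1.7-fold higher number from compound 2 to compound 3 (0.24 log units; within the scatter), toward weaker inhibition, though it might also fall within the scatter. As one of the two values shown rests at the limit of > 250000 nM in this assay, at which 1 of the 2 values shown sits, a limit for compound 3 is also possible. Compound 3 is estimated at 150000 nM, with a range from 50000 nM to 450000 nM.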

Compound 3, half-maximal inhibitory concentration: 42000 nM
Estimate against measurement, compound 3: 3.6-fold (0.55 log units) above, and the stated range ends above it.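

Taking chloro off the 4-chlorophenyl group does not cost activity in this assay: the change to phenyl gives a 2.1-fold lower number from compound 2 to compound 3 (0.32 log units; beyond the scatter), so chloro at this place is not needed for the cytotoxicity seen here. The amino group's place on the other phenyl ring also counts, as 4-aminophenyl in place of 3-aminophenyl gives an at least 5.9-fold lower number from compound 1 to compound 3 (0.77 log units; beyond the scatter), the larger of the two steps shown. That step rests on compound 1, whose value is a limit and not a number: the limit of > 250000 nM in this assay, at which 1 of the 3 values shown sits.

As far as these compounds go, whether hydrogen would also do better than other groups at this place, such as fluoro, methyl or methoxy, remains open. So does whether the amine on the other phenyl ring could give way to a hydroxyl or a carboxylic acid.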